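The source may report more compounds than this note shows. Statements on the series, on what has been measured and on what is new or still open speak of the compounds shown alone.

In a physicochemical assay for solubility, read by nephelometry, measured as kinetic solubility, at pH 6.5 (a lower number here means a less soluble compound, a higher number a more soluble compound), the measured compounds read as follows:

- Compound 1 `COc1ccc(-c2cnc(NC(=O)c3ncc[nH]3)n2C)cc1`: 6.3 ug/mL
- Compound 2 `O=C(Nc1ncc(-c2ccccc2)o1)c1ccc(F)cc1`: 6.3 ug/mL
- Compound 3 `COc1ccc(-c2cnc(NC(=O)c3ccc(F)cc3)n2C)cc1`: < 1.6 ug/mL, a limit of the assay and not a number

Compound 1 stands level with compound 2, and the two cannot be told apart in this assay. The third reading, from compound 3, is the limit of < 1.6 ug/mL in this assay, at which 1 of the 3 values shown sits.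

Compound 4 `Cn1c(-c2ccc(Cl)cc2)cnc1NC(=O)c1ncc[nH]1` has not yet been measured. It differs from compound 1 at one place, with chloro in place of methoxy on an aromatic carbon of a six-membered aromatic ring of carbon only, para to a large group (chloro in place of methoxy on an aromatic carbon).

For the measured compounds named here, only one measured step is available, an at least 3.9-fold lower number from compound 1 to compound 3 (0.59 log units; beyond the scatter), and it replaces 1H-imidazol-2-yl with 4-fluorophenyl on a carbonyl carbon. Compound 4 keeps the 1H-imidazol-2-yl of compound 1, so this step shows how far the reading can move at another place but does not measure the present change. Going by the values given here, no measured step exchanges methoxy for chloro, so no shift beyond the scatter is expected, with only a slight lean towards a lower number. The expected size of the change is a 1.4-fold lower number from compound 1 to compound 4 (0.15 log units; within the scatter). For compound 4 the estimate is 4.5 ug/mL, with an expected range from 1.8 ug/mL to 11 ug/mL.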

Compound 4, solubility: 25 ug/mL
Compound 4: middle estimate off by 5.6-fold (0.74 log units), on the low side, outside the stated range (above it).
By their numbers in this assay, from the lowest: compounds 1 and 2 (each within the scatter of the next); then compound 4. At a limit, below all of these: compound 3.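

In this assay, chloro in place of methoxy on an aromatic carbon, para to a large group, gives a 4.0-fold higher number from compound 1 to compound 4 (0.60 log units; beyond the scatter) and keeps the 1H-imidazol-2-yl on the carbonyl carbon unchanged. The earlier compounds shown here offered only a step at that carbonyl carbon, and it ran towards a lower number; this result shows that the reading also responds to the group at this second place on the core of compound 1, and that here it moves towards a higher number. Nothing given here shows why the exchange of methoxy for chloro moves the reading in this direction.

Methoxy and chloro are the only groups read at this place, and it remains open whether an amine, a carboxylic acid or a nitrile there would give a higher or a lower number in this assay. Also open, from the compounds shown here alone, is whether the same exchange would raise the reading with the 4-fluorophenyl on the carbonyl carbon of compound 3, whose reading of < 1.6 ug/mL is a limit of the assay and not a number.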